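The source may hold more compounds than are shown below. What is called first, only, known or untested is meant among the compounds shown, and "the series" means these compounds.

Measured compounds: compound 1, `Cc1ccc(-c2cs/c(=N/NC(=O)CSc3nnnn3-c3ccccc3)n2-c2ccccc2)cc1`, gives 29.5% in a functional assay on C6 cells (Rattus norvegicus) for cytotoxicity, read by MTT assay, with a stated time of 24 h, tested at 50 ug/mL; a lower number here means a stronger effect, a higher number a weaker effect of the compound at the concentration tested; compound 2, `Cn1cnnc1SCC(=O)N/N=c1/scc(-c2ccccc2)n1-c1ccccc1`, gives 62.4% in this assay.

Compound 2 stands highest of the two numbers in this assay, and its nearest neighbour, compound 1, lies lower by a gap beyond the scatter. Compound 3, `O=C(CSc1nnnn1-c1ccccc1)N/N=c1/scc(-c2ccccc2)n1-c1ccccc1`, has not yet been measured. It differs from compound 2 in one place: 1-phenyl-1H-tetrazol-5-yl in place of 4-methyl-4H-1,2,4-triazol-3-yl on a sulfur. Among the measured compounds shown here, no step between measured compounds is known for this exchange, so its size can only be guessed. Compound 1, which also carries the 1-phenyl-1H-tetrazol-5-yl on a sulfur, gives 29.5%, while compound 2 gives 62.4%; on that basis a downward step from compound 2 to compound 3 of moderate size is expected, a number 20.4 percentage points lower from compound 2 to compound 3 (beyond the scatter). Compound 3 is therefore estimated at 42%, within 26% to 60%.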

Compound 3, a percentage reported as activity, at one concentration (the size of the read-out at that concentration, not a potency): 36.7%
For compound 3 the middle estimate is 5.3 percentage points above the measured one, within the range that was stated.
By their numbers in this assay, from the lowest: compounds 1 and 3 (each within the scatter of the next); then compound 2.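

In this assay, among the compounds shown here, placing 1-phenyl-1H-tetrazol-5-yl instead of 4-methyl-4H-1,2,4-triazol-3-yl on the sulfur gives a number 25.7 percentage points lower from compound 2 to compound 3 (beyond the scatter) as the first direct reading of this exchange, showing that the group at this position affects the read-out. Hydrogen in place of methyl on an aromatic carbon gives a number 7.2 percentage points higher from compound 1 to compound 3 (within the scatter) in the same assay, so this pair shows no separable effect of that methyl when 1-phenyl-1H-tetrazol-5-yl sits on the sulfur. Nothing measured here accounts for the step at the sulfur.

The compounds shown leave open whether the step belongs to the six-membered aromatic ring of 1-phenyl-1H-tetrazol-5-yl or to its five-membered ring, as the exchange alters both at once. They also leave open how an amine or a carboxylic acid on the sulfur would read.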